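A few compounds are considered here, and "the series" means these few. Any claim that something is new, unique, unknown or untested is made for them only; others in the source may bear on it.

Of the compounds shown here, two built on one shared core have been tested in a functional assay on HeLa cells (Homo sapiens) for antiproliferative activity, read by CCK-8 assay, with a stated time of 72 h; on this read-out lower numbers stand for stronger inhibition and higher numbers for weaker inhibition. Compound 1 `O=C(Nc1cccc(-c2oc3cc(-c4ccc(F)cc4)ccc3c(=O)c2O)c1)c1ccc(F)cc1` gives 5350 nM in this assay, and compound 2 `Cc1ccc(C(=O)Nc2cccc(-c3oc4cc(-c5ccc(F)cc5)ccc4c(=O)c3O)c2)cc1` gives 6190 nM. Compound 2 therefore carries the highest of the two numbers, yet the step of a 1.2-fold higher number from compound 1 to compound 2 (0.06 log units; within the scatter) lies within the scatter, so neither compound can be called weaker or stronger. Compound 3 `CCc1ccc(C(=O)Nc2cccc(-c3oc4cc(-c5ccc(F)cc5)ccc4c(=O)c3O)c2)cc1` differs from compound 2 in a single place: methyl in place of hydrogen on a saturated chain carbon bound to an aromatic carbon. Cut one bond further out, this reads as methyl to ethyl, or 4-methylphenyl to 4-ethylphenyl. Among the measured compounds shown here, no measured step touches this chain carbon, and the only step at hand, a 1.2-fold higher number from compound 1 to compound 2 (0.06 log units; within the scatter), concerns a different change and stayed within the scatter. The expected step is a 1.1-fold higher number from compound 2 to compound 3 (0.02 log units; within the scatter), nothing beyond the scatter in either direction. Compound 3 is estimated at 6500 nM, within a range from 3000 nM to 14000 nM.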

Compound 3, half-maximal inhibitory concentration: 21000 nM
Estimate against measurement, compound 3: 3.2-fold (0.51 log units) below; the measured number lies above the stated range.
By their numbers in this assay, from the lowest: compounds 1 and 2 (each within the scatter of the next); then compound 3.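

Changing 4-methylphenyl to 4-ethylphenyl adds a single carbon, yet in this assay it gives a 3.4-fold higher number from compound 2 to compound 3 (0.53 log units; beyond the scatter), so this position does respond to change, which the earlier pair could not show. Ethyl in place of fluoro gives a 3.9-fold higher number from compound 1 to compound 3 (0.59 log units; beyond the scatter), so ethyl separates from both fluoro and methyl, which stayed within the scatter of each other, and it does so towards weaker inhibition. No measurement at hand explains why one extra carbon on the chain has this effect.

Going by these compounds, it remains open whether a longer chain, such as propyl or butyl, would raise the number further or whether the change stops at ethyl. It is also unknown how a branched group such as isopropyl, or a methoxy or an amine at this place, would compare.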